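This account rests on a few compounds, and the source may have more. Where it says the series, first, only, none or still open, it means among the compounds named here.

Series notes. In a functional assay on HSC-3 cells (Homo sapiens) for cytotoxicity, with a stated time of 48 h (a higher number here means that more compound is tolerated, a lower number that less compound is tolerated), compound 1 `Cc1c(C(=O)/C=C/c2cccc([N+](=O)[O-])c2)[n+]([O-])c2ccccc2[n+]1[O-]` gives 122000 nM. In this assay compound 2 `COc1ccc(/C=C/C(=O)c2c(C)[n+]([O-])c3ccccc3[n+]2[O-])cc1` gives 23000 nM, and compound 3 `COc1ccc(/C=C/C(=O)c2c(C)[n+]([O-])c3ccccc3[n+]2[O-])cc1OC` gives 31000 nM. Compound 3 stands second highest of the three numbers: compound 2 is nearest, its number within the scatter of compound 3, while compound 1 is furthest, with a number beyond the scatter. Within the data shown here, the single one-place step measured so far, a 1.3-fold higher number from compound 2 to compound 3 (0.13 log units; within the scatter), is a methoxy in place of hydrogen on an aromatic carbon and stays within the scatter.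

Compound 4 `COc1cc(/C=C/C(=O)c2c(C)[n+]([O-])c3ccccc3[n+]2[O-])cc(OC)c1OC` is not yet measured. Its change from compound 3 is methoxy in place of hydrogen on an aromatic carbon. Among the measured compounds shown here, the only measured step that bears on it is a 1.3-fold higher number from compound 2 to compound 3 (0.13 log units; within the scatter), the same kind of change, and that step was within the scatter. The expectation for compound 4 in this assay is therefore a step of a 1.1-fold higher number from compound 3 to compound 4 (0.05 log units; within the scatter), no movement beyond the scatter. Compound 4 is estimated at 35000 nM, within 15000 nM to 80000 nM.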

Compound 4, half-maximal cytotoxic concentration: 6600 nM
The estimate for compound 4 lay 5.3-fold (0.72 log units) above the measured number; the whole stated range lies above it.
By their numbers in this assay, from the lowest: compound 4; then compounds 2 and 3 (each within the scatter of the next); then compound 1.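

The same change, methoxy in place of hydrogen on an aromatic carbon, does not give the same result at each place on this ring: in this assay the earlier step, a 1.3-fold higher number from compound 2 to compound 3 (0.13 log units; within the scatter), stayed within the scatter, whereas the new one, a 4.7-fold lower number from compound 3 to compound 4 (0.67 log units; beyond the scatter), goes beyond it. Here the entering methoxy stands ortho to a methoxy group, meta to a methoxy group and meta to a large group, and at this place the change lowers the number, so a step measured at one place on the ring cannot be carried over to another. Nothing available explains the difference between the two steps.

Open, going by these compounds, is whether this methoxy would lower the number without the other two methoxy groups on the ring. Also open, on these data alone, is whether a hydroxy group, a fluorine atom or an amine at the same place would give a similar shift.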